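Butyl in place of the aryl group on the amide

This account rests on a few compounds, and the source may have more. Where it says the series, first, only, none or still open, it means among the compounds named here.

Compound 1 `C=CC1=C(C(=O)NCc2ccc(C)cc2)C(c2ccc(F)cc2)OC1` gives 62100 nM in a functional assay on QGY7701 cells (Homo sapiens) for cytotoxicity, read by MTT assay, with a stated time of 24 h; a higher number here means a weaker inhibitor, a lower number a stronger inhibitor.
Compound 2 `C=CC1=C(C(=O)NCc2ccccc2F)C(c2ccc(F)cc2)OC1` gives 51400 nM in this assay.

Compound 2 has the lower of the two numbers, but its gap to compound 1 is within the scatter. Compound 3 `C=CC1=C(C(=O)NCCCCC)C(c2ccc(F)cc2)OC1` carries butyl in place of 2-fluorophenyl on a saturated chain carbon bound to an amide-type nitrogen. Within the data shown here, the only measured step, a 1.2-fold lower number from compound 1 to compound 2 (0.08 log units; within the scatter), exchanges one ring for another at the same place and changes little; no measured step removes the ring altogether. Compound 3 is therefore expected to show no step beyond the scatter, a 1.2-fold higher number from compound 2 to compound 3 (0.07 log units; within the scatter), though the uncertainty is wide. Compound 3 is estimated at 60000 nM, with a range from 25000 nM to 150000 nM.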

Compound 3, half-maximal inhibitory concentration: > 100000 nM
Compound 3 gave a limit, no number; the forecaster's own chance of this, stated with the estimate: 20%; at least 1.6-fold (0.22 log units) between middle value and limit.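

Compound 3 is the first of these compounds to reach a limit of the assay rather than give a number: the limit of > 100000 nM in this assay, at which 1 of the 3 values shown sits.

Where exchanging one ring for another changed little, removing the ring and placing butyl on the saturated chain carbon bound to an amide-type nitrogen gives an at least 1.9-fold higher number from compound 2 to compound 3 (0.28 log units; that floor lies within the scatter) and an at least 1.6-fold higher number from compound 1 to compound 3 (0.20 log units; that floor lies within the scatter). Both floors lie within the scatter, so a real loss is possible at this position but not established.

The compounds shown leave open how large the change is. They also leave open whether a longer chain or a chain ending in an amine would give a number in this assay.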